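Methyl to Phenyl on the Alkylamino Chain

The source may hold more compounds than are shown below. What is called first, only, known or untested is meant among the compounds shown, and "the series" means these compounds.

Measured compounds:
compound 1, `COc1cc2nc(N3CCC(N4CCCC4)CC3)nc(N3CCCCC3)c2cc1OC`, 8%
compound 2, `CCNc1nc(N2CCC(N3CCCC3)CC2)nc2cc(OC)c(OC)cc12`, 3%

In an in vitro functional assay on B300-19 cells for antagonist activity at C-C chemokine receptor type 4 (Homo sapiens), read by GTPgammaS binding, tested at 1 uM (on this read-out lower numbers stand for less inhibition and higher numbers for more inhibition at the one concentration tested (going by the name of the read-out)), compound 2 gives the lowest of the two numbers; its nearest neighbour is compound 1, which sits a step above it by a number 5 percentage points lower from compound 1 to compound 2 (within the scatter), a step that lies within the scatter and concerns a different change, piperidin-1-yl against ethylamino on an aromatic carbon. Compound 3, `COc1cc2nc(N3CCC(N4CCCC4)CC3)nc(NCc3ccccc3)c2cc1OC`, differs from compound 2 by phenyl in place of methyl on a saturated chain carbon bound to a nitrogen on an aromatic ring, read one bond further out as ethylamino to benzylamino. Among the measured compounds shown here, no measured step touches this saturated chain carbon, so nothing in these two numbers gives the change a direction. Since both known values lie low and within scatter of each other, compound 3 is expected to show a step of a number 5 percentage points higher from compound 2 to compound 3 (within the scatter) in this assay, that is, none beyond the scatter. The estimate for compound 3 is 8%, with a range from -10% to 30%.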

Compound 3, a percentage reported as inhibition, at one concentration (the size of the read-out at that concentration, not a potency): 10%
For compound 3 the middle estimate is 2 percentage points below the measured one; low and high end bracket the measured number.
By their numbers in this assay, from the lowest: compounds 2, 1 and 3 (each within the scatter of the next).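

At the saturated chain carbon bound to a nitrogen on an aromatic ring, phenyl in place of methyl gives a number 7 percentage points higher from compound 2 to compound 3 (within the scatter) in this assay, so this position now has a measured step, and going from ethylamino to benzylamino does nothing beyond the scatter. On the aromatic carbon, benzylamino in place of piperidin-1-yl gives a number 2 percentage points higher from compound 1 to compound 3 (within the scatter), so benzylamino, like ethylamino, stays within the scatter of piperidin-1-yl. Nothing available accounts for these small steps.

All the steps shown lie within the scatter, and it remains open whether any change at this place can lift the inhibition clear of it. Also open, as far as these compounds go, is what a longer chain such as phenethylamino, or a chain ending in an amine or a carboxylic acid, would give here.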